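The compounds below may be only part of what the source reports. "The series", "measured", "known", "first", "only" and "open" are said of these compounds alone.

For the measured compounds named here, compound 1 `COc1cc(-c2cc(/C=C/C(=O)c3ccc(N)cc3)[nH]n2)cc(OC)c1OC` gives 73200 nM in a functional assay on NCI-H23 cells (Homo sapiens) for inhibition, read by sulforhodamine B assay, with a stated time of 48 h (a lower number here means that less compound is tolerated, a higher number that more compound is tolerated), the lowest of the two numbers so far, and compound 2 `COc1ccc(-c2cc(/C=C/C(=O)c3ccc(N)cc3)[nH]n2)cc1OC` gives 95600 nM; the step of a 1.3-fold higher number from compound 1 to compound 2 (0.12 log units; within the scatter) concerns hydrogen in place of methoxy on an aromatic carbon. Compound 3 `COc1ccc(C(=O)/C=C/c2cc(-c3cc(OC)c(OC)c(OC)c3)n[nH]2)cc1` differs from compound 1 by methoxy in place of amino on an aromatic carbon. Going by the values given here, no measured step bears on this change; the only step recorded, hydrogen in place of methoxy, sits elsewhere in the structure and stays within the scatter. With nothing pointing either way, the expected step is a 1.1-fold higher number from compound 1 to compound 3 (0.04 log units; within the scatter), within the scatter. Compound 3 is therefore estimated at 80000 nM, with a range of 35000 nM to 180000 nM.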

Compound 3, concentration lethal to 50% of the cells: > 100000 nM
Compound 3 ended at the assay's limit (the forecaster's own chance of this, stated with the estimate: 20%); middle value at least 1.2-fold (0.09 log units) away from the limit.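

Methoxy in place of amino, para to a large group, is the first change read at this position, and its step is an at least 1.3-fold higher number from compound 1 to compound 3 (0.13 log units; that floor lies within the scatter). That step is only a floor, so it shows no clear difference between the two groups and sets no upper bound on the change. Compound 3 gives > 100000 nM in this assay, which is a limit of the assay and not a number: the limit of > 100000 nM in this assay, at which 1 of the 3 values shown sits.

As far as these compounds go, how far compound 3 lies past that limit stays open. Also open, from the compounds shown here alone, is what a hydroxyl, a dimethylamino group or a carboxylic acid would give in this place.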